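Compound 3 to Compound 4: Ethoxy Gives Way to Benzyloxy

The source may hold more compounds than are shown below. What is called first, only, known or untested is meant among the compounds shown, and "the series" means these compounds.

Compounds measured in a functional assay on Vero cells (Chlorocebus sabaeus) for inhibition; a lower number here means a stronger inhibitor, a higher number a weaker inhibitor:
- Compound 1 `CSc1ccc(Cn2cnc3c(-c4ccco4)ncnc32)cc1`: 6.9 ug/mL
- Compound 2 `Clc1ccc(Cn2cnc3c(-c4ccco4)ncnc32)cc1`: > 62.5 ug/mL, a limit of the assay
- Compound 3 `CCOc1ccc(Cn2cnc3c(-c4ccco4)ncnc32)cc1`: 37.4 ug/mL

Among the measured compounds shown here, of the two actual numbers in this assay, the one for compound 3, 37.4 ug/mL, is the higher. The value of compound 2 is only a limit, so it gives no exact position.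

Compound 4 `c1ccc(COc2ccc(Cn3cnc4c(-c5ccco5)ncnc43)cc2)cc1` is the next to be measured. Its difference from compound 3 is phenyl in place of methyl on a saturated chain carbon bound to an oxygen on an aromatic ring, so ethoxy becomes benzyloxy.

For the measured compounds named here, no measured step makes this change. The nearest evidence comes from swapping the whole group on the aromatic carbon, which gave a 5.4-fold higher number from compound 1 to compound 3 (0.73 log units; beyond the scatter), an at least 9.0-fold higher number from compound 1 to compound 2 (0.95 log units; beyond the scatter) and an at least 1.6-fold lower number from compound 2 to compound 3 (0.22 log units; that floor lies within the scatter). These steps show that the number can respond to this group, but they do not give the direction for the new change. The expectation therefore stays anchored on compound 3 at 37.4 ug/mL, with no step beyond the scatter expected. The expected step is a 1.2-fold lower number from compound 3 to compound 4 (0.10 log units; within the scatter). For compound 4 the estimated value is 30 ug/mL, with an expected range of 10 ug/mL to 62.5 ug/mL.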

Compound 4, half-maximal inhibitory concentration: 1.7 ug/mL
Beside the measured number, compound 4's estimate is 18-fold (1.25 log units) above it, outside the stated range (below it).
By their numbers in this assay, from the lowest: compound 4; then compound 1; then compound 3. At a limit, above all of these: compound 2.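

In this assay, the number proved sensitive to the group on the saturated chain carbon bound to an oxygen on an aromatic ring, and not only to swaps of the whole group on the aromatic carbon: phenyl in place of methyl gave a 22-fold lower number from compound 3 to compound 4 (1.34 log units; beyond the scatter). Benzyloxy also surpassed methylsulfanyl, the best group among the earlier compounds, with a 4.1-fold lower number from compound 1 to compound 4 (0.61 log units; beyond the scatter), so compound 3 alone had not shown what an oxygen-linked group can reach at this place. Against chloro the change reads an at least 36-fold lower number from compound 2 to compound 4 (1.56 log units; beyond the scatter), but this is only a floor, since the value of compound 2 is a limit of the assay: the limit of > 62.5 ug/mL in this assay, at which 1 of the 4 values shown sits.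

As far as these compounds go, a single pair, compound 3 and compound 4, carries this change, so it remains open whether the aromatic ring itself matters or whether other replacements for methyl would do the same. A cyclohexyl group, a longer chain or an amine on that same carbon would separate these readings, and the compounds shown say nothing about any of them.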